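A few compounds are considered here, and "the series" means these few. Any claim that something is new, unique, unknown or untested is made for them only; others in the source may bear on it.

Values in a functional assay on HCT-116 cells (Homo sapiens) for cytotoxicity, read by MTT assay, with a stated time of 72 h; a higher number here means a weaker inhibitor, a lower number a stronger inhibitor:

- compound 1 `O=C1c2c[n+]([O-])c3ccccc3c2C(=O)c2c1c1ccccc1n2Cc1cn([C@@H]2C[C@H](O)[C@@H](CO)O2)nn1`: 50 nM
- compound 2 `O=C1c2c[n+]([O-])c3ccccc3c2C(=O)c2c1c1ccccc1n2Cc1cn(CC(O)CO)nn1`: 250 nM
- compound 3 `CN1CCN(CCCn2c3c(c4ccccc42)C(=O)c2c[n+]([O-])c4ccccc4c2C3=O)CC1`: 560 nM

Compound 2, at 250 nM, holds the middle place of the three, with compound 1 lower (stronger) and compound 3 higher (weaker). The next compound to consider is compound 4 `O=C1c2c[n+]([O-])c3ccccc3c2C(=O)c2c1c1ccccc1n2Cc1cn([C@H]2C[C@H](O)[C@@H](CO)O2)nn1`, which is not yet measured. Relative to compound 2, it swaps the open chain for a ring: 4-hydroxy-5-(hydroxymethyl)oxolan-2-yl in place of 2,3-dihydroxypropyl on an aromatic nitrogen. Going by the values given here, the group that enters has the same name as the one in compound 1, but the two structures are not drawn identically in their stereochemistry.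

The most relevant evidence is therefore a 5.0-fold higher number from compound 1 to compound 2 (0.70 log units; beyond the scatter), read in reverse, since it is the same exchange of groups. The step of a 2.2-fold higher number from compound 2 to compound 3 (0.35 log units; beyond the scatter) changes a different group and says little here. A drop in this assay is expected, though perhaps a smaller one, as the match with compound 1 is not exact. The estimated change is a 2.8-fold lower number from compound 2 to compound 4 (0.44 log units; beyond the scatter). For compound 4 the expected value is 90 nM, with an estimated range of 30 nM to 270 nM.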

Compound 4, half-maximal inhibitory concentration: 120 nM
Compound 4: middle estimate off by 1.3-fold (0.12 log units), on the low side; low and high end bracket the measured number.
By their numbers in this assay, from the lowest: compound 1; then compound 4; then compound 2; then compound 3.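

In this assay the ring keeps an advantage over the open chain even with a changed stereocentre, with a 2.1-fold lower number from compound 2 to compound 4 (0.32 log units; beyond the scatter), so the gain seen with compound 1 is not tied to that one drawn configuration. Configuration still counts at this position, with a 2.4-fold higher number from compound 1 to compound 4 (0.38 log units; beyond the scatter). This gap can be traced to a single stereocentre at a saturated ring carbon, drawn S in compound 1 and R in compound 4, because of one plain fact: the fact that compounds 1 and 4 differ only in the configuration as drawn

The compounds shown vary only one of the three stereocentres of the 4-hydroxy-5-(hydroxymethyl)oxolan-2-yl group, so the role of the other two stays open. Also open, going by these compounds, is how a group of a different kind on the same aromatic nitrogen, such as a longer chain ending in a carboxylic acid, would compare with the ring.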